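A few compounds are considered here, and "the series" means these few. Any claim that something is new, unique, unknown or untested is made for them only; others in the source may bear on it.

Measured compounds:
compound 1, `O=C(CN1CCC(c2ccccn2)CC1)Nc1c(Cl)cc(Cl)cc1Cl` — in a functional assay on HEK293 cells for agonist activity at D(4) dopamine receptor (Homo sapiens), read by FLIPR (a lower number here means that less compound is needed, a higher number that more compound is needed for the effect), compound 1 gives 145 nM
compound 2, `O=C(CN1CCC(c2cccc[n+]2[O-])CC1)Nc1ccc(F)cc1F` — in this assay compound 2 gives 103 nM
compound 3, `O=C(CN1CCC(c2cccc[n+]2[O-])CC1)Nc1cccc(Cl)c1Cl` — in this assay compound 3 gives 180 nM

The three compounds share one core, and all three numbers lie within the usual scatter of one another. Within the data shown here, compound 3 gives a number close to that of compound 1, and the only single-point step among them, a 1.7-fold higher number from compound 2 to compound 3 (0.24 log units; within the scatter), stays within the scatter as well. Compound 4, `CSc1cccc(NC(=O)CN2CCC(c3cccc[n+]3[O-])CC2)c1`, has not yet been measured in this assay. It differs from compound 3 in one place: 3-(methylsulfanyl)phenyl in place of 2,3-dichlorophenyl on an amide-type nitrogen. Among the measured compounds shown here, the one measured step that bears on this change is the exchange of one aryl group for another on the same amide-type nitrogen, a 1.7-fold higher number from compound 2 to compound 3 (0.24 log units; within the scatter), which did not move the number beyond the scatter. On that basis no step beyond the scatter is expected in this assay, in either direction. Compound 4 is therefore estimated at 150 nM, with a range from 50 nM to 450 nM. The step this estimate implies, a 1.2-fold lower number from compound 3 to compound 4 (0.08 log units; within the scatter), is expected to remain within the scatter.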

Compound 4, half-maximal effective concentration: 100 nM
Estimate against measurement, compound 4: 1.5-fold (0.18 log units) above; the measured number falls inside the stated range.
By their numbers in this assay, from the lowest: compounds 4, 2, 1 and 3 (each within the scatter of the next).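

At this place on an amide-type nitrogen, this assay now includes an aryl group without halogen: 3-(methylsulfanyl)phenyl, which contains sulfur and counts one hydrogen-bond acceptor. It stands in for 2,3-dichlorophenyl with a 1.8-fold lower number from compound 3 to compound 4 (0.26 log units; within the scatter) and for 2,4-difluorophenyl with a 1.0-fold lower number from compound 2 to compound 4 (0.01 log units; within the scatter) and neither step leaves the scatter. Across compound 2, compound 3 and compound 4, then, replacing chlorine or fluorine with this sulfur-bearing group leaves the number within the scatter, and nothing available accounts for this result.

It remains open whether any group at this place can move the number beyond the scatter, since the three aryl groups shown do not. An aryl group carrying a carboxylic acid or an amine, or a cyclohexyl group in place of the aryl group, would test this.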